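Cyclohexyl in place of propyl in compound 2

The source may report more compounds than this note shows. Statements on the series, on what has been measured and on what is new or still open speak of the compounds shown alone.

In an in vivo ADME assay on the whole organism (strain Sprague-Dawley) for pharmacokinetics, with Rattus norvegicus as the target (a higher number here means that more of the compound sits outside the plasma, a lower number that more of the compound stays in the plasma), compound 1 `CC(C)[C@@H]1NC[C@@H](C)Oc2ccccc2CCCNC(=O)[C@@H](Cc2ccc(F)cc2)NC(=O)[C@@H](C)N(C)C1=O` gives 2 L/kg. Compound 2 `CCC[C@@H]1NC[C@@H](C)Oc2ccccc2CCCNC(=O)[C@@H](Cc2ccc(F)cc2)NC(=O)[C@@H](C)N(C)C1=O` gives 1.7 L/kg, and compound 3 `C[C@@H]1CN[C@@H](C2CC2)C(=O)N(C)[C@H](C)C(=O)N[C@H](Cc2ccccc2)C(=O)NCCCc2ccccc2O1` gives 1.3 L/kg. Compound 2 therefore lies within the scatter of both other compounds, and the numbers show no clear order around it.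

Compound 4 `C[C@@H]1CN[C@@H](C2CCCCC2)C(=O)N(C)[C@H](C)C(=O)N[C@H](Cc2ccc(F)cc2)C(=O)NCCCc2ccccc2O1` has not yet been measured. It differs from compound 2 by cyclohexyl in place of propyl on a saturated ring carbon, next to the ring nitrogen: cyclohexyl in place of propyl on a saturated ring carbon. Among the measured compounds shown here, only one measured step bears on this carbon, propyl in place of isopropyl, and a 1.2-fold lower number from compound 1 to compound 2 (0.07 log units; within the scatter) stays within the scatter. For the measured compounds named here, that step involves no ring, and no measured compound carries cyclohexyl, so it offers only loose guidance. No shift beyond the scatter is therefore expected in this assay. The estimated step is a 1.2-fold higher number from compound 2 to compound 4 (0.07 log units; within the scatter), which would stay within the scatter. Compound 4 is expected at 2 L/kg, with an estimated range of 1.1 L/kg to 3.6 L/kg.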

Compound 4, volume of distribution at steady state: 4.7 L/kg
Beside the measured number, compound 4's estimate is 2.4-fold (0.37 log units) below it; the whole stated range lies below it.
By their numbers in this assay, from the lowest: compounds 3, 2 and 1 (each within the scatter of the next); then compound 4.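

In this assay, this ring carbon proved able to move the number beyond the scatter: cyclohexyl gives a 2.8-fold higher number from compound 2 to compound 4 (0.44 log units; beyond the scatter) and, set against isopropyl, a 2.4-fold higher number from compound 1 to compound 4 (0.37 log units; beyond the scatter) as well. The earlier step between propyl and isopropyl had stayed within the scatter, so only now does the group at this carbon show a measurable effect on the read-out, and it does so from either chain-bearing compound. Nothing measured here accounts for this shift.

The compounds shown leave open whether the rise follows from the ring itself or from the larger carbon count, which a longer chain such as hexyl could separate. They also leave open how cyclopentyl, phenyl or a piperidine ring carrying an amine nitrogen would behave at this carbon.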